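Iodo on the ring of compound 3: an open question

This account rests on a few compounds, and the source may have more. Where it says the series, first, only, none or still open, it means among the compounds named here.

Compounds measured so far:
compound 1, `COc1ccc(/C=C/c2cc(=O)cco2)cc1`, 377 uM
compound 2, `COc1ccc(/C=C/c2cc(=O)cco2)cc1OC`, 635 uM
compound 3, `COc1ccc(C2CC(=O)C=CO2)cc1`, 197 uM

Of the compounds shown here, three have been tested in a functional assay on 786-0 cells (Homo sapiens) for inhibition, read by sulforhodamine B assay, with a stated time of 48 h; a lower number here means a stronger inhibitor of growth, a higher number a weaker inhibitor of growth. For the measured compounds named here, compound 1 gives 377 uM, and compound 2 gives 635 uM; the one step between them, a 1.7-fold higher number from compound 1 to compound 2 (0.23 log units; within the scatter), is a methoxy in place of hydrogen on an aromatic carbon. Compound 3, with a saturated core in place of the double bond, gives 197 uM, the lowest of the three numbers, though its gap to compound 1 lies within the scatter and only its gap to compound 2 lies beyond it.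

Compound 4, `COc1ccc(C2CC(=O)C(I)=CO2)cc1`, has not yet been tested. It differs from compound 3 in one place: iodo in place of hydrogen on a double-bonded ring carbon. Going by the values given here, no measured step touches this ring carbon, and the only step in hand, from compound 1 to compound 2, concerns an aromatic carbon and stays within the scatter. Nothing in the data therefore points to a step in either direction, so compound 4 is expected to give about the same number as compound 3 in this assay, the expected step being a 1.0-fold higher number from compound 3 to compound 4 (0.01 log units; within the scatter). The estimate for compound 4 is 200 uM, expected to fall between 70 uM and 600 uM.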

Compound 4, concentration for growth inhibition (reported as GI): 27 uM
Compound 4: middle estimate off by 7.4-fold (0.87 log units), on the high side; measured number outside the range, below it.
By their numbers in this assay, from the lowest: compound 4; then compounds 3, 1 and 2 (each within the scatter of the next, the first and the last beyond it).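

In this assay, iodo in place of hydrogen on the double-bonded ring carbon gives a clear change, a 7.3-fold lower number from compound 3 to compound 4 (0.86 log units; beyond the scatter), and this step lies beyond the scatter. For the compounds shown here, the only earlier one-place step, a 1.7-fold higher number from compound 1 to compound 2 (0.23 log units; within the scatter), concerned an aromatic carbon and stayed within the scatter, so this ring carbon, two ring bonds from the ring oxygen, is the first place where a change of one heavy atom moves the number beyond the scatter. No measurement available here accounts for the size or direction of the step, which therefore stands as an observation about this one pair.

The compounds shown leave open whether the step belongs to iodine itself or would also follow from another group on the same ring carbon, such as chloro, bromo, methyl or an amine. They also leave open whether iodo on the corresponding carbon of the core of compound 1, which keeps the double bond that compound 3 lacks, would give a step of similar size.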